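Furanylethyl Amide in Place of Difluorobenzyl: Expected Tolerance

The source may report more compounds than this note shows. Statements on the series, on what has been measured and on what is new or still open speak of the compounds shown alone.

Compound 2 `Cc1cc(C)cc(S(=O)(=O)c2c(C(=O)NCc3cccc(F)c3F)[nH]c3ccc(Cl)cc23)c1` is known in an ADME assay on MT4 cells (Homo sapiens) for cytotoxicity, read by MTT assay (a lower number here means that less compound is tolerated, a higher number that more compound is tolerated), only as a limit of the assay, reported as > 51100 nM. The numbered values around it come from two related amides: compound 1 `Cc1cc(C)cc(S(=O)(=O)c2c(C(=O)NC(C)C(=O)NCc3ccccc3F)[nH]c3ccc(Cl)cc23)c1` gives 23300 nM in this assay, and compound 3 `Cc1cc(C)cc(S(=O)(=O)c2c(C(=O)NCC(=O)NCCn3c(C)cnc3[N+](=O)[O-])[nH]c3ccc(Cl)cc23)c1` gives 24500 nM. One of the three results therefore sits at the limit (the limit of > 51100 nM in this assay, at which 1 of the 3 values shown sits), while the other two are measured numbers.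

Compound 4 `Cc1cc(C)cc(S(=O)(=O)c2c(C(=O)NC(C)c3ccco3)[nH]c3ccc(Cl)cc23)c1` arises from compound 2 through the change (1-(furan-2-yl)ethyl in place of 2,3-difluorobenzyl on an amide-type nitrogen). Going by the values given here, no step between measured compounds covers this exchange. The account therefore expects the step of an at least 1.3-fold lower number from compound 2 to compound 4 (0.12 log units; that floor lies within the scatter) to lie within the scatter, or at most a modest move toward less tolerated. Compound 4 is estimated at 38000 nM, with a range from 15000 nM to 100000 nM.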

Compound 4, half-maximal cytotoxic concentration: > 54700 nM
Compound 4: only a limit was reported; the forecaster's own chance of this, stated with the estimate: 40%; middle value at least 1.4-fold (0.15 log units) from the limit.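

In this assay, compound 4 reaches a limit of the assay, > 54700 nM, so a 1-(furan-2-yl)ethyl group on the amide-type nitrogen gives a second result at a limit, after the 2,3-difluorobenzyl group. Compound 2 is also known only as a limit, so the step between these two cannot be read. Furan-2-yl in place of (2-fluorobenzyl)carbamoyl on the saturated chain carbon gives an at least 2.3-fold higher number from compound 1 to compound 4 (0.37 log units; beyond the scatter).

From the compounds shown here alone, the actual values of compound 2 and compound 4 remain open. So does the reading in this assay for a 1-(pyridin-2-yl)ethyl group on the same nitrogen.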